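Methyl for Hydrogen on the Amide-Bearing Ring

The source may hold more compounds than are shown below. What is called first, only, known or untested is meant among the compounds shown, and "the series" means these compounds.

Measured so far in a physicochemical assay for solubility, in phosphate buffer, measured as kinetic solubility, with a stated time of 18 h, at pH 7.4; a lower number here means a less soluble compound, a higher number a more soluble compound:
compound 1 `CC(Cl)C(=O)Nc1cccc(-c2nc3ccccc3s2)c1` gives 830 nM
compound 2 `O=C(Nc1cccc(-c2nc3ccccc3s2)c1)c1cnccc1Cl` gives 320 nM

Compound 2 stands at the lower of the two numbers in this assay. Going by the values given here, the one step on record, a 2.6-fold lower number from compound 1 to compound 2 (0.41 log units; beyond the scatter), brings it there from compound 1, and that step exchanges the whole group on the carbonyl carbon.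

Compound 3 `Cc1ccc(-c2nc3ccccc3s2)cc1NC(=O)c1cnccc1Cl` keeps the acyl group of compound 2 and differs from it only by methyl in place of hydrogen on an aromatic carbon. Among the compounds with values here, no measured pair shows a methyl entering for a hydrogen on this ring, so the recorded step gives no direct guidance; it only shows that the shared core tolerates changes of this assay's scale. For a single added carbon with no donor or acceptor, the step of a 1.3-fold lower number from compound 2 to compound 3 (0.11 log units; within the scatter) is expected to be small, most likely within the scatter, with a slight lean downward. The estimate for compound 3 is 250 nM, with a range from 100 nM to 700 nM.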

Compound 3, solubility: 140 nM
Beside the measured number, compound 3's estimate is 1.8-fold (0.25 log units) above it; the range from low to high includes it.
By their numbers in this assay, from the lowest: compound 3; then compound 2; then compound 1.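

In this assay, methyl in place of hydrogen on an aromatic carbon, ortho to a large group and para to a group of 9 heavy atoms, gives a 2.3-fold lower number from compound 2 to compound 3 (0.36 log units; beyond the scatter). This is the first change shown on this ring rather than on the carbonyl carbon, and it shows that one added carbon, with no hydrogen-bond donor or acceptor, can produce a modest step beyond the scatter at this position. Nothing measured on these compounds accounts for the fall in the number.

Going by these compounds, whether an amine, a methoxy group or a longer chain at the same position would move the number in the same direction remains open. On these data alone, it is also open whether the methyl would give a step of this size with the 1-chloroethyl group of compound 1 on the carbonyl carbon.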